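From Iodo to Methoxy in a Small Amine Series

The source may hold more compounds than are shown below. What is called first, only, known or untested is meant among the compounds shown, and "the series" means these compounds.

In a functional assay on HeLa cells (Homo sapiens) for antiproliferative activity, with a stated time of 48 h (on this read-out lower numbers stand for stronger inhibition and higher numbers for weaker inhibition), compound 3 `Nc1ccc(/C=C/C(=O)c2ccc(I)cc2)cc1` gives 58000 nM. Compound 2 `Nc1ccc(/C=C/C(=O)c2ccc(F)cc2)cc1` gives 40000 nM, so these two free amines sit level within the scatter. Compound 1 `C=C(Br)C(=O)Nc1ccc(/C=C/C(=O)c2ccc(OC)cc2)cc1` gives 1400 nM, a clearly lower number than either of them.

The open question is compound 4 `COc1ccc(C(=O)/C=C/c2ccc(N)cc2)cc1`, which follows from compound 3 by one exchange, methoxy in place of iodo on an aromatic carbon. Among the measured compounds shown here, only one measured step bears directly on this place. Going from compound 2 to compound 3, iodo in place of fluoro gave a 1.5-fold higher number from compound 2 to compound 3 (0.16 log units; within the scatter), so that exchange left the read-out within the scatter. Compound 1 carries the methoxy group too, but its nitrogen is acylated as a bromo-substituted acrylamide, whereas compound 4 keeps the free amine. The value of compound 1, 1400 nM, therefore cannot be read as the outcome of the methoxy exchange alone. With only two halogens measured, the data do not show how a methoxy group behaves on the free amine, so no step beyond the scatter is expected.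

The expected change is a 1.5-fold lower number from compound 3 to compound 4 (0.16 log units; within the scatter). For compound 4 the estimated value is 40000 nM, with an expected range from 15000 nM to 90000 nM.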

Compound 4, half-maximal inhibitory concentration: 98000 nM
The estimate for compound 4 lay 2.5-fold (0.39 log units) below the measured number; the measured number lies above the stated range.
By their numbers in this assay, from the lowest: compound 1; then compounds 2, 3 and 4 (each within the scatter of the next, the first and the last beyond it).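

In this assay, among the compounds shown here, methoxy on the free amine stays level with iodo, at a 1.7-fold higher number from compound 3 to compound 4 (0.23 log units; within the scatter), but the same place shows a 2.5-fold higher number from compound 2 to compound 4 (0.39 log units; beyond the scatter), so this is the first exchange on this aromatic carbon to clear the scatter, though only modestly and only against fluoro. With fluoro, iodo and methoxy, all three free amines still give high numbers, so methoxy on this carbon does not by itself bring the read-out near that of compound 1. With methoxy held constant, hydrogen in place of (1-bromoethenyl)carbonyl on the nitrogen gives a 70-fold higher number from compound 1 to compound 4 (1.85 log units; beyond the scatter), a large step that places the low number of compound 1 with the substituted nitrogen rather than with the methoxy group.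

Nothing available explains the gap between methoxy and fluoro or the size of the step at the nitrogen.

Still open, on these data alone, is whether the (1-bromoethenyl)carbonyl group would give a similar step with fluoro or iodo on the aromatic carbon, or whether a plain acetyl group on the nitrogen would do the same. The compounds shown also leave open how a carboxylic acid or an amine would read on this aromatic carbon.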